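This account rests on a few compounds, and the source may have more. Where it says the series, first, only, none or still open, it means among the compounds named here.

Measured so far in a functional assay on K562 cells (Homo sapiens) for inhibition; on this read-out lower numbers stand for stronger inhibition and higher numbers for weaker inhibition:

- Compound 1 `Cc1cc(-c2ccc(Cl)cc2)cc(=O)o1`: in this assay compound 1 gives > 50000 nM, a limit of the assay rather than a number.
- Compound 2 `Cc1ccc(-c2cc(C)oc(=O)c2)cc1`: in this assay compound 2 gives > 50000 nM, likewise a limit.
- Compound 3 `Cc1cc(/C=C/c2ccccc2)cc(=O)o1`: in this assay compound 3 gives > 50000 nM, again a limit.

Compound 2 thus stands at the limit of the assay, and so do the other two values shown; all three sit at the limit of > 50000 nM in this assay, at which 3 of the 3 values shown sit. Going by the values given here, the single one-place step present, a step that the two limits leave unreadable from compound 1 to compound 2, runs between two limits and its size cannot be read. Among the compounds with values here, no gradation among the measured compounds is visible, so no compound can be called stronger or weaker than another.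

Compound 4 `Cc1cc(-c2ccc(C=O)cc2)cc(=O)o1` is the next compound to be measured. Relative to compound 2 the change is formyl in place of methyl on an aromatic carbon. Within the data shown here, no measured step bears readably on this change, since the only step in hand is unreadable at both ends. With every measured compound at the limit, the expectation for compound 4 is that it remains there as well. The step this estimate implies, a number no higher from compound 2 to compound 4 (the limit leaves the size open), is expected to be none beyond the scatter. Compound 4 is therefore expected to give about 50000 nM in this assay, with a range of 15000 nM to 150000 nM, most likely reported only as a limit.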

Compound 4, half-maximal inhibitory concentration: 26000 nM
The estimate for compound 4 lay 1.9-fold (0.28 log units) above the measured number; low and high end bracket the measured number.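

In this assay, compound 4 is the first compound shown to give a number rather than a limit, so this aromatic carbon can carry a group that brings the read-out within the measurable range. Formyl in place of methyl gives an at least 1.9-fold lower number from compound 2 to compound 4 (0.28 log units; that floor lies within the scatter), and formyl in place of chloro gives an at least 1.9-fold lower number from compound 1 to compound 4 (0.28 log units; that floor lies within the scatter); both are floors, so the true size of each step remains unknown and neither establishes a change beyond the scatter. Compound 4 is the only compound in the set with a measured number, and the other three values are limits: the limit of > 50000 nM in this assay, at which 3 of the 4 values shown sit.

As far as these compounds go, whether an amine, a carboxylic acid or a hydroxymethyl group at this aromatic carbon would also give a number in this assay remains open, as does whether the formyl result depends on its oxygen or on some other feature of the group. From the compounds shown here alone, with a single number in hand, no ranking of groups at this position can be drawn, and the true values of compound 1 and compound 2 remain unknown.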